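The source may hold more compounds than are shown below. What is called first, only, known or untested is meant among the compounds shown, and "the series" means these compounds.

Compound 1 `O=C(/C=C/CNCCOc1ccc(Oc2c(-c3ccc(F)cc3)sc3cc(O)ccc23)cc1)N1CCCCC1`: in a functional assay on MDA-MB-231 cells (Homo sapiens) for antiproliferative activity, read by CCK-8 assay, with a stated time of 48 h (a higher number here means a weaker inhibitor, a lower number a stronger inhibitor), compound 1 gives > 50000 nM, which is a limit of the assay rather than a number.
Compound 2 `O=C(/C=C/CN1CC(Oc2ccc(Oc3c(-c4ccc(F)cc4)sc4cc(O)ccc34)cc2)C1)N1CCCC1`: compound 2 gives > 50000 nM, again a limit of the assay and not a number.

Both measured compounds share the same core and differ only in the linker that carries the unsaturated amide. Within the data shown here, compound 2 stands at the limit of > 50000 nM in this assay, at which 2 of the 2 values shown sit; there is no number to place it against, and no step between the measured compounds can be drawn, since neither value is a number. Compound 3 `CNC(=O)/C=C/CN1CC(Oc2ccc(Oc3c(-c4ccc(F)cc4)sc4cc(O)ccc34)cc2)C1` is compound 2 with a change at the amide end: methylamino in place of pyrrolidin-1-yl on a carbonyl carbon. The measured pair gives no sign that the group on the carbonyl carbon decides the outcome. Because the measured values all lie on (the limit of > 50000 nM in this assay, at which 2 of the 2 values shown sit), the step that the limit leaves unreadable from compound 2 to compound 3 is expected to be none beyond the scatter, with the result most likely again reported as a limit. Compound 3 is therefore estimated at 60000 nM, within a range from 15000 nM to 250000 nM.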

Compound 3, half-maximal inhibitory concentration: > 50000 nM
Compound 3 ended at the assay's limit (the forecaster's own chance of this, stated with the estimate: 80%); the middle value is on the limit's open side.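

No step can be read from compound 2 to compound 3, since neither result is a number: the limit of > 50000 nM in this assay, at which 3 of the 3 values shown sit.

The compounds shown leave open whether pyrrolidin-1-yl and methylamino on the carbonyl carbon differ at all in this assay and what structure, if any, would give a measurable value there.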